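A few compounds are considered here, and "the series" means these few. Any claim that something is new, unique, unknown or untested is made for them only; others in the source may bear on it.

In an ADME assay on RD cells (Homo sapiens) for cytotoxicity, read by MTT assay, with a stated time of 24 h (on this read-out higher numbers stand for lower toxicity in this test and lower numbers for higher toxicity in this test), compound 1 `CCO/N=C/c1ccc(OCCCCCN2CCN(c3ccnc(N)c3)C2=O)cc1` gives 59000 nM and compound 3 `CC(CCOc1ccc(-c2noc(C(C)(C)C)n2)cc1)CCN1CCN(c2ccnc(N)c2)C1=O` gives 55000 nM. Compound 3 holds the lowest of the two numbers, and its nearest neighbour, compound 1, sits within the scatter of it. Compound 2 `CCO/N=C/c1ccc(OCC#CCN2CCN(c3ccnc(N)c3)C2=O)cc1` reaches only a limit of this assay, > 100000 nM, which is the line (the limit of > 100000 nM in this assay, at which 1 of the 3 values shown sits). Compound 4 `CCONCc1ccc(OCCC(C)CCN2CCN(c3ccnc(N)c3)C2=O)cc1` has not yet been tested. It differs from compound 3 in one place ((ethoxyamino)methyl in place of 5-(tert-butyl)-1,2,4-oxadiazol-3-yl on an aromatic carbon). Among the measured compounds shown here, no measured step of this kind is available, so the expectation rests on the range seen so far. Compound 4 is expected to show no step beyond the scatter, about a 1.1-fold higher number from compound 3 to compound 4 (0.04 log units; within the scatter), so its estimated value in this assay is 60000 nM within 30000 nM to 100000 nM.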

Compound 4, half-maximal cytotoxic concentration: 7370 nM
Compound 4: the middle estimate sits 8.1-fold (0.91 log units) above what was measured; measured number outside the range, below it.
By their numbers in this assay, from the lowest: compound 4; then compounds 3 and 1 (each within the scatter of the next). At a limit, above all of these: compound 2.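

Replacing 5-(tert-butyl)-1,2,4-oxadiazol-3-yl with (ethoxyamino)methyl on this aromatic carbon, para to a large group, gives a 7.5-fold lower number from compound 3 to compound 4 (0.87 log units; beyond the scatter) in this assay. Among the compounds shown here, this is the first measured step here, and it shows that a change at this one place can move the number beyond the scatter, towards higher toxicity in this test. Nothing measured here accounts for the step.

From the compounds shown here alone, whether it comes from losing the ring or from gaining the (ethoxyamino)methyl stays open. A carboxylic acid or a plain aminomethyl on the same carbon could help to separate the two.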